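The source may hold more compounds than are shown below. What is called first, only, known or untested is meant among the compounds shown, and "the series" means these compounds.

Measured so far:
- Compound 1, `O=C1CSc2ccccc2N1Cc1cn(-c2ccc([N+](=O)[O-])cc2)nn1`: 35.8%
- Compound 2, `O=C1CSc2ccccc2N1Cc1cn(Cc2cccc([N+](=O)[O-])c2)nn1`: 20.1%

Of the compounds shown here, two sharing one core have been tested in an ADME assay on HeLa cells (Homo sapiens) for antiproliferative activity, read by MTT assay, with a stated time of 72 h, tested at 30 ug/mL; a lower number here means a weaker effect, a higher number a stronger effect of the compound at the concentration tested. Of the two numbers, compound 2 gives the lowest, and its nearest neighbour, compound 1, lies beyond the scatter above it. Going by the values given here, compound 1 carries its nitrophenyl group directly on the aromatic nitrogen, whereas compound 2 carries it on a saturated chain carbon bound to that nitrogen, so the two values do not isolate a single change and no step between measured compounds can be drawn from them.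

Compound 3, `O=C1CSc2ccccc2N1Cc1cn(Cc2ccc([N+](=O)[O-])cc2)nn1`, keeps the saturated chain carbon of compound 2 and differs only in the position of the nitro group on the ring: 4-nitrophenyl in place of 3-nitrophenyl on a saturated chain carbon bound to an aromatic nitrogen. Among the compounds with values here, no measured pair shows what this change alone does in this assay, so any expectation rests on the closeness of the two structures rather than on a recorded step. A modest move upward is expected, with the step from compound 2 to compound 3 estimated at a number 5.9 percentage points higher from compound 2 to compound 3 (within the scatter), which may yet fall within the scatter. Compound 3 is therefore expected to give about 26%, within a range from 12% to 40%.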

Compound 3, a percentage reported as activity, at one concentration (the size of the read-out at that concentration, not a potency) in the HeLa assay: 55.5%
Estimate against measurement, compound 3: 29.5 percentage points below; the measured number lies above the stated range.
By their numbers in the HeLa assay, from the lowest: compound 2; then compound 1; then compound 3.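

Compound 2 and compound 3 contain the same atoms, yet in the HeLa assay replacing 3-nitrophenyl with 4-nitrophenyl gives a number 35.4 percentage points higher from compound 2 to compound 3 (beyond the scatter), the first single-change step available in this small set. In the HeLa assay compound 2 gives 20.1% and compound 3 gives 55.5%. On a saturated chain carbon bound to an aromatic nitrogen, therefore, this read-out responds strongly to how the nitrophenyl group is arranged, even though the counted features of the two groups are identical. In a physicochemical assay, read by spectrophotometry (a lower number here means a stronger inhibitor, a higher number a weaker inhibitor), compound 2 gives 34.1 ug/mL and compound 3 gives 27.4 ug/mL. In the physicochemical assay the same change gives a 1.2-fold lower number from compound 2 to compound 3 (0.10 log units; within the scatter), so the clear separation seen in the HeLa assay has no counterpart in the physicochemical assay, and nothing shown here accounts for the difference.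

The compounds shown do not reveal whether the gain belongs to the nitro group itself or would persist with an amine or a carboxylic acid on the ring in its place, or with a longer chain joining that ring to the aromatic nitrogen. Because the cell read-out comes from a single concentration, it also leaves open how potent compound 3 would prove across a range of concentrations.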